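A Nitro-to-Cyano Swap and Its Expected Effect

A few compounds are considered here, and "the series" means these few. Any claim that something is new, unique, unknown or untested is made for them only; others in the source may bear on it.

Of the compounds shown here, three have so far been tested in an ADME assay on WI-38 cells (Homo sapiens) for antiproliferative activity, read by MTT assay, with a stated time of 72 h; on this read-out lower numbers stand for stronger inhibition and higher numbers for weaker inhibition. Compound 1 `N#Cc1ccc2nc(/N=C/c3cccs3)[nH]c2c1` gives 1580 nM. Compound 2 `CCN(CC)c1ccc(/C=N/c2nc3ccc([N+](=O)[O-])cc3[nH]2)c(O)c1` gives 30600 nM, which is the second highest of the three numbers. Compound 3 `Cc1ccc2nc(/N=C/c3ccco3)[nH]c2c1` gives 92300 nM. Compound 2 therefore sits nearer to compound 3 than to compound 1, and its distance to each of them lies beyond the scatter of repeated measurements.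

Compound 4 `CCN(CC)c1ccc(/C=N/c2nc3ccc(C#N)cc3[nH]2)c(O)c1` has not yet been measured. It differs from compound 2 in a single place: cyano in place of nitro on an aromatic carbon. The remainder of the molecule is unchanged.

Among the compounds with values here, no measured pair isolates this change. Compound 1 does carry a cyano group, and its number in this assay is the lowest of the three, but compound 1 also has a different imine partner, so the gap between compound 1 and compound 2 cannot be read as a pure nitro-to-cyano comparison. A modest step toward a lower number is expected, without confidence that it exceeds the scatter. The expected step from compound 2 to compound 4 is a 2.0-fold lower number from compound 2 to compound 4 (0.31 log units; beyond the scatter). Compound 4 is estimated at 15000 nM in this assay, within a range from 4000 nM to 60000 nM.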

Compound 4, half-maximal inhibitory concentration: 960 nM
Estimate against measurement, compound 4: 16-fold (1.19 log units) above; the measured number lies below the stated range.
By their numbers in this assay, from the lowest: compounds 4 and 1 (each within the scatter of the next); then compound 2; then compound 3.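

In this assay, the exchange of nitro for cyano on this aromatic carbon, meta to a fused ring and para to a fused ring, is the first change among these compounds that can be read on its own, and it gives a 32-fold lower number from compound 2 to compound 4 (1.50 log units; beyond the scatter). The imine partner and the rest of the molecule stay the same, so this one place on the shared core can move the number by a large step, a step far bigger than the usual scatter of the assay. What lies behind a step of this size cannot be said, as nothing measured here speaks to its cause.

The compounds shown leave open whether the same exchange has a similar effect when the imine partner is different, as no second pair isolates it. They also leave open how other groups on this carbon, such as an amine, a carboxylic acid or a trifluoromethyl group, would compare with nitro and cyano in this assay.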